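A few compounds are considered here, and "the series" means these few. Any claim that something is new, unique, unknown or untested is made for them only; others in the source may bear on it.

Measured compounds in an ADME assay on BHK cells (Mesocricetus auratus) for cytotoxicity, read by MTT assay, with a stated time of 96 h; a lower number here means that less compound is tolerated, a higher number that more compound is tolerated:

Compound 1 `CCC(=O)Nc1ccc(-c2nc3cc(C(F)(F)F)ccc3n2C2CCCCC2)cc1` gives 15000 nM.
Compound 2 `O=C(O)CCC(=O)Nc1ccc(-c2nc3cc(C(F)(F)F)ccc3[nH]2)cc1` gives > 100000 nM, which is a limit of the assay and not a number.
Compound 3 `CCC(=O)Nc1ccc(-c2nc3cc(C(F)(F)F)ccc3[nH]2)cc1` gives 100000 nM.

Compound 3 holds the highest of the two numbers shown, and the nearest number belongs to compound 1, with a step of a 6.7-fold higher number from compound 1 to compound 3 (0.82 log units; beyond the scatter), the change being hydrogen in place of cyclohexyl on an aromatic nitrogen. Compound 2 sits at the limit of > 100000 nM in this assay, at which 1 of the 3 values shown sits, so the step of a number no higher from compound 2 to compound 3 (the limit leaves the size open) cannot be sized.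

Compound 4 `CCN(CC)CC(=O)Nc1ccc(-c2nc3cc(C(F)(F)F)ccc3[nH]2)cc1` differs from compound 3 in one place: diethylamino in place of methyl on a saturated chain carbon bound to a carbonyl carbon. Among the measured compounds shown here, no measured step covers this change. For the measured compounds named here, the only step touching the same chain, from compound 2 to compound 3, involves a carboxy and ends at a limit, so it gives no readable size. Nothing shown therefore points to a shift beyond the scatter, and compound 4 is expected to stay close to compound 3, with an expected step of a 1.3-fold lower number from compound 3 to compound 4 (0.10 log units; within the scatter). Compound 4 is thus estimated at 80000 nM, between 25000 nM and 100000 nM, with a fair chance that only a limit is reported.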

Compound 4, half-maximal cytotoxic concentration: 23000 nM
Compound 4: the middle estimate sits 3.5-fold (0.54 log units) above what was measured; measured number outside the range, below it.
By their numbers in this assay, from the lowest: compounds 1 and 4 (each within the scatter of the next); then compound 3.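

In this assay, the saturated chain carbon bound to a carbonyl carbon proves sensitive to what it carries: replacing methyl with diethylamino, which brings 5 heavy atoms including a nitrogen in place of 1 carbon, gives a 4.3-fold lower number from compound 3 to compound 4 (0.64 log units; beyond the scatter). Among the compounds shown here, this is the first step at this chain whose size can be read, and it shows that less compound is tolerated once the amine is present, a change that compound 3 and compound 2 alone could not reveal. With diethylamino in place of carboxymethyl, the same position gives an at least 4.3-fold lower number from compound 2 to compound 4 (0.63 log units; beyond the scatter), and the size of this step stays open at its upper end since compound 2 stands at a limit and not a number: the limit of > 100000 nM in this assay, at which 1 of the 4 values shown sits.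

The compounds shown do not separate the effect of the nitrogen from that of the added carbons, which a plain butyl chain or a smaller dimethylamino at this carbon would begin to do. Also open, as far as these compounds go, is whether the nitrogen must carry open chains, as a piperidine or morpholine ring in its place would test, and whether cyclohexyl on the aromatic nitrogen adds to the diethylamino change.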